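The compounds below may be only part of what the source reports. "The series", "measured", "known", "first", "only" and "open" are said of these compounds alone.

Measured compounds in a physicochemical assay for solubility; a lower number here means a less soluble compound, a higher number a more soluble compound:

- compound 1, `CNC(=O)c1cc(C(=O)NCCCC2CNCCO2)cn(Cc2ccccc2)c1=O`: >= 194 ug/mL, a limit of the assay rather than a number.
- compound 2, `CNC(=O)c1cc(C(=O)NC2CC2)c(C)n(Cc2ccccc2)c1=O`: >= 126 ug/mL, a limit of the assay.
- compound 3, `CNC(=O)c1cc(C(=O)NC2CC2)cn(Cc2cccc3cc[nH]c23)c1=O`: >= 144 ug/mL, a limit of the assay.

Compound 3 therefore stands at the limit of >= 144 ug/mL in this assay, at which 1 of the 3 values shown sits; no numeric solubility is known for it. Among the measured compounds shown here, none of the three measured compounds has a number below its limit, so no step between measured compounds can be sized, and the three values give no sense of how far the series lies above these limits.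

Compound 4, `CNC(=O)c1cc(C(=O)NC2CC2)cn(Cc2cccc3[nH]ncc23)c1=O`, is the next compound for this assay. It differs from compound 3 in one place: 1H-indazol-4-yl in place of 1H-indol-7-yl on a saturated chain carbon bound to an aromatic nitrogen. The shared core and the cyclopropyl amide are unchanged. For the measured compounds named here, with no measured step to lean on, the expected step in this assay is one of no size beyond the usual scatter, in neither direction, and the most probable outcome is that the assay again reports only a limit for compound 4.

The estimate for compound 4 in this assay is 150 ug/mL, within a range of 60 ug/mL to 350 ug/mL. This estimate means a step that the limit leaves unreadable from compound 3 to compound 4, which is expected to stay within the scatter.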

Compound 4, solubility: 10 ug/mL
The estimate for compound 4 lay 15-fold (1.18 log units) above the measured number; the measured number lies below the stated range.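

In this assay, among the compounds shown here, the change from 1H-indol-7-yl to 1H-indazol-4-yl on a saturated chain carbon bound to an aromatic nitrogen gives the first step that can be sized: an at least 14-fold lower number from compound 3 to compound 4 (1.15 log units; beyond the scatter). The earlier compounds shown here, all reported only as limits, gave no sign that this position could matter so much. Compound 4, at 10 ug/mL, is the only one shown with a measured number. The two groups match in their counts of heavy atoms and hydrogen-bond donors, yet 1H-indazol-4-yl has one more ring nitrogen, one more hydrogen-bond acceptor and a different point of attachment, and nothing shown gives a cause for the step.

The change alters the ring nitrogen count and the point of attachment together, so 1H-indol-4-yl and 1H-indazol-7-yl would be needed to tell which of the two goes with the step. From the compounds shown here alone, it also remains open whether an amine or a carboxylic acid added to 1H-indazol-4-yl would change the number in this assay.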